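The source may report more compounds than this note shows. Statements on the series, on what has been measured and on what is new or still open speak of the compounds shown alone.

Of the compounds shown here, three have been measured so far in an ADME assay (Rattus norvegicus, strain Wistar Han) for metabolic stability; a lower number here means that the compound disappears faster, a higher number that the compound lasts longer. Compound 1 `CCn1c(-c2ccc(C(F)(F)F)nc2)nc2c(O[C@H]3CCN(C(=O)N4CC(OC)C4)C3)ncnc21` gives 2 h. Compound 2 `CCn1c(-c2cnc(C)nc2)nc2c(O[C@H]3CCN(C(=O)C4CC(F)(F)C4)C3)ncnc21` gives 1.4 h. Compound 3 `CCn1c(-c2cnc(C)nc2)nc2c(O[C@H]3CCN(C(=O)C4CCOC4)C3)ncnc21` gives 1.4 h, which stands level with compound 2 and, together with it, is the lowest of the three numbers, while the gap to compound 1 lies within the scatter.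

Within the data shown here, only one single-point step has been measured: no change at the digits printed from compound 2 to compound 3 (within the scatter), an exchange of oxolan-3-yl for 3,3-difluorocyclobutyl on a carbonyl carbon that left this assay unchanged.

The next compound, compound 4 `CCn1c(-c2cnc(C)nc2)nc2c(O[C@H]3CCN(C(=O)N4CC(OC)C4)C3)ncnc21`, differs from compound 3 as follows: 3-methoxyazetidin-1-yl in place of oxolan-3-yl on a carbonyl carbon. The group that enters here is the same 3-methoxyazetidin-1-yl that compound 1 carries on a carbonyl carbon, and compound 1 sits within the scatter of compound 3. Among the measured compounds shown here, since the one measured exchange at this carbonyl carbon produced no change, no step beyond the scatter is expected from compound 3 to compound 4, giving a 1.1-fold higher number from compound 3 to compound 4 (0.06 log units; within the scatter). For compound 4 the estimated half-life in this assay is 1.6 h, with a range from 0.9 h to 2.8 h.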

Compound 4, half-life: 1.7 h
The estimate for compound 4 lay 1.1-fold (0.03 log units) below the measured number, and the stated range covers the measured number.
By their numbers in this assay, from the lowest: compounds 2, 3, 4 and 1 (each within the scatter of the next).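

With 2-methylpyrimidin-5-yl held fixed, placing 3-methoxyazetidin-1-yl on the carbonyl carbon gives a 1.2-fold higher number from compound 3 to compound 4 (0.08 log units; within the scatter) and a 1.2-fold higher number from compound 2 to compound 4 (0.08 log units; within the scatter) in this assay, so three different groups at this place now read alike, among them a four-membered ring attached through its nitrogen. Among these compounds, the first step at the aromatic carbon, 2-methylpyrimidin-5-yl in place of 6-(trifluoromethyl)pyridin-3-yl, gives a 1.2-fold lower number from compound 1 to compound 4 (0.07 log units; within the scatter), which shows that this second place has not moved the half-life beyond the scatter either. No other measurement is available here to explain these results.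

From the compounds shown here alone, whether an amine or a carboxylic acid on the carbonyl carbon would shift the half-life beyond the scatter remains open. So does the effect of a plain phenyl ring on the aromatic carbon.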